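A few compounds are considered here, and "the series" means these few. Any claim that something is new, unique, unknown or untested is made for them only; others in the source may bear on it.

Within the data shown here, compound 2 `Cc1ccc2nc(NC(=O)CCCCC(=O)NO)sc2c1` stands at the higher of the two numbers so far recorded in a functional assay on PC-3 cells (Homo sapiens) for cytotoxicity; a lower number here means a stronger inhibitor, a higher number a weaker inhibitor: compound 2 gives 6.23 ug/mL, and the gap to compound 1 lies beyond the usual scatter. Compound 1 `COc1ccc2nc(NC(=O)CCCCCCC(=O)NO)sc2c1` gives 1.56 ug/mL in this assay; compound 1 and compound 2 differ in more than one place, so that gap cannot be assigned to any single change. Compound 3 `COc1ccc2nc(NC(=O)CCCCC(=O)NO)sc2c1` differs from compound 2 by methoxy in place of methyl on an aromatic carbon. Among the measured compounds shown here, no measured pair isolates this change. For compound 3 only a small step toward a lower number is expected, a 1.6-fold lower number from compound 2 to compound 3 (0.19 log units; within the scatter), within the scatter. The estimate for compound 3 in this assay is 4 ug/mL, with a range from 1.5 ug/mL to 10 ug/mL.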

Compound 3, half-maximal inhibitory concentration: 15.3 ug/mL
The estimate for compound 3 lay 3.8-fold (0.58 log units) below the measured number, outside the stated range (above it).
By their numbers in this assay, from the lowest: compound 1; then compound 2; then compound 3.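

In this assay methoxy in place of methyl on the aromatic carbon raises the number (a 2.5-fold higher number from compound 2 to compound 3 (0.39 log units; beyond the scatter)), so on this shorter chain, methyl gives the stronger inhibitor of the two. With methoxy held on the ring, hydroxycarbamoyl in place of 2-(hydroxycarbamoyl)ethyl gives the larger step (a 9.8-fold higher number from compound 1 to compound 3 (0.99 log units; beyond the scatter)), so chain length also matters in this series. Nothing at hand bears on the cause of either step.

As far as these compounds go, whether methyl also outperforms methoxy on the longer chain of compound 1 remains open. So does the outcome with a fluorine or an amine at this aromatic carbon, or with a still longer chain.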